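This account rests on a few compounds, and the source may have more. Where it says the series, first, only, none or still open, it means among the compounds named here.

Three related thiosemicarbazones have been measured in a physicochemical assay for lipophilicity; a higher number here means a more lipophilic compound, a lower number a more polar compound. Compound 1 `COc1ccc(OC/C=N/NC(N)=S)cc1` gives 2.09, compound 2 `NC(=S)N/N=C/COc1ccc(Br)cc1` gives 2.9, and compound 3 `NC(=S)N/N=C/c1ccc(F)cc1` gives 2.18. Compound 2 therefore stands highest of the three: its nearest neighbour is compound 3, and compound 1 lies furthest from it. Among the measured compounds shown here, the one step between two measured compounds that differ in a single place is the change from compound 1 to compound 2, bromo in place of methoxy on an aromatic carbon, which moved a number 0.81 log units higher from compound 1 to compound 2 (beyond the scatter).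

Compound 4 `NC(=S)N/N=C/COc1ccccc1` has not yet been measured in this assay. It differs from compound 2 in a single place: hydrogen in place of bromo on an aromatic carbon. For the measured compounds named here, no measured pair here shows hydrogen in place of bromo directly, so the step from compound 1 to compound 2 is the only guide, and it suggests that the group being removed had raised the number. Compound 4 is therefore expected to come out lower than compound 2, with an estimated step of a number 0.80 log units lower from compound 2 to compound 4 (beyond the scatter), placing compound 4 at an expected 2.1 within a range of 1.7 to 2.5.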

Compound 4, partition coefficient: 2.01
Beside the measured number, compound 4's estimate is 0.09 log units above it, within the range that was stated.
By their numbers in this assay, from the lowest: compounds 4, 1 and 3 (each within the scatter of the next); then compound 2.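

With hydrogen in place of bromo on the aromatic carbon, para to a group of 8 heavy atoms, the read-out in this assay shows a number 0.89 log units lower from compound 2 to compound 4 (beyond the scatter) and so sets compound 2 apart from the hydrogen compound as well as from the methoxy compound. Hydrogen in place of methoxy at the same position gives a number 0.08 log units lower from compound 1 to compound 4 (within the scatter) and thus separates neither compound from the other, so of the three groups seen here, only bromo stands apart at this position. Nothing available gives a measured reason for this difference.

As far as these compounds go, whether chloro, an amine or a carboxylic acid at this position would fall with bromo or with hydrogen and methoxy remains open. So does whether the bromo step would carry over to a core other than the one shared by compounds 1, 2 and 4.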